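Series notes: furan-2-yl in place of 4-methylphenyl

The source may hold more compounds than are shown below. What is called first, only, known or untested is meant among the compounds shown, and "the series" means these compounds.

Compound 1 `Cc1ccc(-c2noc(COc3ccc(CCC(=O)O)cc3)n2)cc1` is the reference point of this pair of notes. Going by the values given here, in a functional assay on CHO cells for agonist activity at Free fatty acid receptor 1 (Homo sapiens), read by FLIPR and calcium flux, in the presence of a further agent that is not named here (on this read-out higher numbers stand for an effect only at larger amounts of compound and lower numbers for an effect already at smaller amounts), compound 1 gives 300 nM, the lowest of the two numbers measured so far. Among the compounds with values here, the only other measured member, compound 2 `CC(Oc1ccc(CCC(=O)O)cc1)c1nc(-c2ccccc2)no1`, differs from compound 1 in more than one place, so no single step can be read between them; in this assay compound 2 gives 2390 nM, a higher number than compound 1 and beyond the usual scatter.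

Compound 3 `O=C(O)CCc1ccc(OCc2nc(-c3ccco3)no2)cc1` has not yet been measured. It differs from compound 1 by one change: furan-2-yl in place of 4-methylphenyl on an aromatic carbon.

Within the data shown here, no step between measured compounds is available for this particular change. Among the measured compounds shown here, the expectation for this assay is that the step of a 2.7-fold higher number from compound 1 to compound 3 (0.43 log units; beyond the scatter) will be a moderate rise in the number, since the one comparison in hand, compound 2 at 2390 nM, went to a higher number when the 4-methylphenyl of compound 1 was no longer present, though that comparison also carries a second change. Compound 3 is therefore estimated at 800 nM, with a range from 300 nM to 2500 nM.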

Compound 3, half-maximal effective concentration: > 100000 nM
Compound 3 gave a limit, no number (the forecaster's own chance of this, stated with the estimate: 10%); middle value at least 120-fold (2.09 log units) from the limit.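

On the aromatic carbon between two ring nitrogen atoms, the aryl group matters far more than compound 2 could suggest: in this assay, furan-2-yl in place of 4-methylphenyl gives an at least 330-fold higher number from compound 1 to compound 3 (2.52 log units; beyond the scatter) and the activity of compound 1 is not retained. Going by these compounds alone, this is the first single-change reading at this place, since compound 2 carries a second change and offers no clean comparison, and it shows that an aromatic ring here does not by itself preserve a measurable response. Going by these compounds, the reading for compound 3 is a limit of the assay and not a number, so the true size of the loss stays unknown: the limit of > 100000 nM in this assay, at which 1 of the 3 values shown sits.

The change replaces a six-membered carbon ring with a five-membered ring holding a ring oxygen and also removes the methyl group, so the compounds shown do not separate ring size, the ring oxygen and the methyl group from one another. Still open, on these data alone, is whether thiophen-2-yl, or an unsubstituted phenyl on the otherwise unchanged core of compound 1, would stay close to compound 1 or fall to the same limit.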